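The source may hold more compounds than are shown below. What is called first, only, known or untested is meant among the compounds shown, and "the series" means these compounds.

For the measured compounds named here, in an ADME assay on S9 fraction from liver (Homo sapiens) for metabolic stability, with a stated time of 1 h (a higher number here means that more of the compound is left, a lower number that less of the compound is left), compound 2 (`N#Cc1cnc(NCc2cnccc2C(F)(F)F)cc1N[C@H]1CC[C@@H](O)CC1`) gives 33% and holds the middle of the three numbers so far. Compound 1 (`N#Cc1cnc(NCc2cnccc2C(F)(F)F)cc1N[C@H]1C[C@@H](O)C1`) gives 90% at the top and compound 3 (`N#Cc1cnc(NCc2ccccc2C(F)(F)F)cc1N[C@H]1CC[C@@H](O)CC1`) gives 0% at the bottom, both beyond the scatter from compound 2.

The next structure is compound 4 (`N#Cc1cnc(NCc2cnccc2C(F)(F)F)cc1NC[C@H]1CC[C@H](O)CC1`), with (4-hydroxycyclohexyl)methyl in place of 4-hydroxycyclohexyl on a nitrogen on an aromatic ring. The nearest measured evidence is the change at that same place, 4-hydroxycyclohexyl in place of 3-hydroxycyclobutyl, which gave a large step (a number 57 percentage points lower from compound 1 to compound 2 (beyond the scatter)) beyond the scatter. Going by the values given here, no measured step goes from 4-hydroxycyclohexyl to (4-hydroxycyclohexyl)methyl, so that step is only a loose guide. A smaller downward move in this assay is therefore expected, and the estimated step (a number 13 percentage points lower from compound 2 to compound 4 (beyond the scatter)) carries wide uncertainty. For compound 4 the estimate is 20% with an expected range from 4% to 45% for this compound.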

Compound 4, percent of the compound remaining: 32%
Beside the measured number, compound 4's estimate is 12 percentage points below it; measured number inside the range.
By their numbers in this assay, from the lowest: compound 3; then compounds 4 and 2 (each within the scatter of the next); then compound 1.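

In this assay, (4-hydroxycyclohexyl)methyl in place of 4-hydroxycyclohexyl on a nitrogen on an aromatic ring gives no change beyond the scatter (a number 1 percentage points lower from compound 2 to compound 4 (within the scatter)), so adding one carbon to the group at this position does not alter the read-out for this pair. The 3-hydroxycyclobutyl group keeps its lead over the extended group as well (a number 58 percentage points lower from compound 1 to compound 4 (beyond the scatter)), which means that both groups carrying a six-membered ring now stand well under compound 1. No measurement at hand bears on the origin of these results.

Open, on these data alone, is whether a longer chain on that nitrogen, or an amine in place of the hydroxyl on the six-membered ring, would hold the number at this level. Also open, as far as these compounds go, are (3-hydroxycyclobutyl)methyl at this position and the (4-hydroxycyclohexyl)methyl group on the core of compound 3.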